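Thiophene for furan on the chlorinated core

The source may report more compounds than this note shows. Statements on the series, on what has been measured and on what is new or still open speak of the compounds shown alone.

The compounds share one nucleoside-like core that carries a five-membered heteroaryl group and a halogen. Compound 1 `OC[C@H]1O[C@@H](n2cc(F)c3c(-c4ccoc4)ncnc32)[C@H](O)[C@@H]1O` is measured in an ADME assay on MRC5 cells (Homo sapiens) for cytotoxicity, read by MTT assay, with a stated time of 72 h (a lower number here means that less compound is tolerated, a higher number that more compound is tolerated), and gives 15400 nM. Compound 2 `OC[C@H]1O[C@@H](n2cc(F)c3c(-c4cccs4)ncnc32)[C@H](O)[C@@H]1O` differs from compound 1 in thiophen-2-yl in place of furan-3-yl on an aromatic carbon. In this assay compound 2 gives 47200 nM, which makes the step of a 3.1-fold higher number from compound 1 to compound 2 (0.49 log units; beyond the scatter). Compound 3 `OC[C@H]1O[C@@H](n2cc(Cl)c3c(-c4ccoc4)ncnc32)[C@H](O)[C@@H]1O` stands on the second core, which differs from the core of compound 1 in chloro in place of fluoro on an aromatic carbon. For compound 3 the result in this assay is only a limit of the assay, > 50000 nM. The step from compound 1 to compound 3 is thus an at least 3.2-fold higher number from compound 1 to compound 3 (0.51 log units; beyond the scatter) and is open at its upper end because the limit of > 50000 nM in this assay, at which 1 of the 3 values shown sits, caps what can be read.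

Compound 4 `OC[C@H]1O[C@@H](n2cc(Cl)c3c(-c4cccs4)ncnc32)[C@H](O)[C@@H]1O` is not yet measured. Among the compounds with values here, it carries the same change as the one from compound 1 to compound 2, now set on the core of compound 3: thiophen-2-yl in place of furan-3-yl on an aromatic carbon. Both place descriptions agree word for word, so this is the same change, made twice among the four compounds. The expected step from compound 3 to compound 4 in this assay is a step that the limit leaves unreadable from compound 3 to compound 4, set beside the measured 3.1-fold higher number from compound 1 to compound 2 (0.49 log units; beyond the scatter), and rests on compound 2 moving toward the tolerated side from compound 1. Compound 3 is already reported only as a limit. For compound 4 the expected value in this assay is therefore 120000 nM, between 50000 nM and 300000 nM, and most likely it will again be reported only as a limit.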

Compound 4, half-maximal cytotoxic concentration: > 50000 nM
Compound 4 ended at the assay's limit; the forecaster's own chance of this, stated with the estimate: 85%; the middle value does not contradict the limit.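

In this assay compound 4 gives > 50000 nM, which is a limit of the assay and not a number. The change from furan-3-yl to thiophen-2-yl can thus be read only on the core of compound 1, as a 3.1-fold higher number from compound 1 to compound 2 (0.49 log units; beyond the scatter), while the step on the core of compound 3 cannot be read, so these data neither show that the change carries over from one core to the other nor show that it fails to. The chloro in place of fluoro change gives a second pair, an at least 1.0-fold higher number from compound 2 to compound 4 (0.02 log units; that floor lies within the scatter), and this floor says little on its own, so the two readings of that change cannot be called alike or different: the same change on two cores in this assay, an at least 3.2-fold higher number (0.51 log units; beyond the scatter) from compound 1 to compound 3 and an at least 1.0-fold higher number (0.02 log units; that floor lies within the scatter) from compound 2 to compound 4; the limit leaves it open whether they differ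

Still open, on these data alone, is how far compound 3 and compound 4 lie from each other, since neither has a readable number in this assay, and only a measurement that reaches past the limit could settle whether the thiophen-2-yl change keeps its direction on the chlorinated core. Also open, as far as these compounds go, is whether an amine or a carboxylic acid in place of the five-membered aromatic ring, or bromo in place of the halogen, would give a readable number on either core.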